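The source may hold more compounds than are shown below. What is called first, only, known or untested is meant among the compounds shown, and "the series" means these compounds.

Series notes. Compound 1 `COc1ccc(OC)c(/C=N/c2c(C#N)ncn2-c2ccc(F)cc2)c1` and compound 2 `N#Cc1ncn(-c2ccc(F)cc2)c1/N=C/c1ccc([N+](=O)[O-])cc1` carry different cores; the difference between the two cores is not broken down here. In a functional assay on A549 cells (Homo sapiens) for antiproliferative activity, read by MTT assay, with a stated time of 48 h (a higher number here means a weaker inhibitor, a lower number a stronger inhibitor), compound 1 gives 9280 nM, and compound 2 gives 18100 nM. Compound 3 `COc1ccc(OC)c(/C=N/c2c(C#N)ncn2Cc2ccc(F)cc2)c1` differs from compound 1 by 4-fluorobenzyl in place of 4-fluorophenyl on an aromatic nitrogen, and in this assay compound 3 gives 13100 nM; this change produced a 1.4-fold higher number from compound 1 to compound 3 (0.15 log units; within the scatter). Compound 4 `N#Cc1ncn(Cc2ccc(F)cc2)c1/N=C/c1ccc([N+](=O)[O-])cc1` differs from compound 2 by 4-fluorobenzyl in place of 4-fluorophenyl on an aromatic nitrogen, the same change made on the core of compound 2. Going by the values given here, only one earlier instance of this change exists, so the expectation rests on that single step. For compound 4 in this assay a step of a 1.3-fold higher number from compound 2 to compound 4 (0.12 log units; within the scatter) is expected because compound 2 gives 18100 nM and the earlier instance gave a 1.4-fold higher number from compound 1 to compound 3 (0.15 log units; within the scatter). The estimated value for compound 4 is 24000 nM, with a range from 10000 nM to 55000 nM.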

Compound 4, half-maximal inhibitory concentration: 2020 nM
Compound 4: the middle estimate sits 12-fold (1.07 log units) above what was measured; the whole stated range lies above it.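

In this assay the change to 4-fluorobenzyl in place of 4-fluorophenyl on an aromatic nitrogen gives a 9.0-fold lower number from compound 2 to compound 4 (0.95 log units; beyond the scatter) on the core of compound 2. The step does not carry over from one core to the other: the same change on two cores in this assay, a 1.4-fold higher number (0.15 log units; within the scatter) from compound 1 to compound 3 and a 9.0-fold lower number (0.95 log units; beyond the scatter) from compound 2 to compound 4, 13-fold (1.10 log units) apart, beyond the scatter of two such steps

The size of this step therefore differs with the core in these two pairs, but two pairs cannot show which difference between the cores matters or how the step would run on a further core.

Still open, going by these compounds, is whether a longer chain carrying the 4-fluorophenyl group on that aromatic nitrogen would continue the step seen on the core of compound 2. Also open, on these data alone, is how an amine in place of the fluorine of the 4-fluorobenzyl group would read.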